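From ethoxy to methylsulfanyl in a potent series

This account rests on a few compounds, and the source may have more. Where it says the series, first, only, none or still open, it means among the compounds named here.

Measured in a functional assay on HeLa cells (Homo sapiens) for antiproliferative activity, read by MTT assay, with a stated time of 72 h; on this read-out higher numbers stand for weaker inhibition and lower numbers for stronger inhibition:
Compound 1 `CCOc1ccc(-c2ncnn2-c2cc(OC)c(OC)c(OC)c2)cc1Cl`: 6 nM
Compound 2 `CCOc1ccc(-c2ncnn2-c2cc(OC)c(OC)c(OC)c2)cc1`: 15 nM
Compound 3 `COc1ccc(-n2ncnc2-c2cc(OC)c(OC)c(OC)c2)cc1`: > 10000 nM, which is a limit

Of the two exact numbers, the higher belongs to compound 2, at 15 nM, so it is the less potent of that pair. Compound 4 `COc1cc(-n2ncnc2-c2ccc(SC)cc2)cc(OC)c1OC` has methylsulfanyl in place of ethoxy on an aromatic carbon, para to a large group: methylsulfanyl in place of ethoxy on an aromatic carbon. Within the data shown here, the only measured single-place step is a 2.5-fold higher number from compound 1 to compound 2 (0.40 log units; beyond the scatter). It is modest and concerns a different change, hydrogen in place of chloro, so it is only a loose guide. In this assay, a small step at most is therefore expected, if anything toward a higher number. The expected step is a 1.7-fold higher number from compound 2 to compound 4 (0.22 log units; within the scatter). Compound 4 is estimated at 25 nM, with an expected range of 6 nM to 120 nM.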

Compound 4, half-maximal inhibitory concentration: 150 nM
Compound 4: the middle estimate sits 6.0-fold (0.78 log units) below what was measured, outside the stated range (above it).
By their numbers in this assay, from the lowest: compound 1; then compound 2; then compound 4. At a limit, above all of these: compound 3.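

At this aromatic carbon, para to a large group, methylsulfanyl in place of ethoxy is not a neutral swap in this assay: the change gives a 10-fold higher number from compound 2 to compound 4 (1.00 log units; beyond the scatter). That step is larger than the only earlier one, a 2.5-fold higher number from compound 1 to compound 2 (0.40 log units; beyond the scatter), so this position tolerates less change than the chloro-to-hydrogen step suggested. Nothing measured here accounts for the size of the new step.

Still open, going by these compounds, is whether the sulfur or the shorter chain matters more. An ethylsulfanyl group at this position would separate the two.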